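Cyclohexyl Ether Replaces Thioether in a Cytotoxicity Series

This account rests on a few compounds, and the source may have more. Where it says the series, first, only, none or still open, it means among the compounds named here.

Compound 3 `Cc1cc(SC2CCCCC2)nc(Nc2ccc(C#N)cc2)n1` reaches only a limit in an ADME assay on MT4 cells (Homo sapiens) for cytotoxicity, read by MTT assay; on this read-out lower numbers stand for higher toxicity in this test and higher numbers for lower toxicity in this test: its value of >= 192000 nM is a limit of the measurement, not a number, and it stands at the limit of >= 192000 nM in this assay, at which 1 of the 3 values shown sits. In this assay compound 1 `Cc1cc(OC2CCCC2)nc(Nc2ccc(C#N)cc2)n1` gives 1050 nM, and compound 2 `N#Cc1ccc(Nc2nccc(OC3CCCCC3)n2)cc1` gives 322000 nM. For the measured compounds named here, the one measured step bearing on the series is an at least 180-fold higher number from compound 1 to compound 3 (2.26 log units; beyond the scatter), in which cyclopentyloxy became cyclohexylsulfanyl. Compound 4 `Cc1cc(OC2CCCCC2)nc(Nc2ccc(C#N)cc2)n1` reverses the sulfur-for-oxygen part of that step: cyclohexyloxy in place of cyclohexylsulfanyl on an aromatic carbon. With the ether restored on a six-membered ring, a lower number than the limit of compound 3 is expected, though how far it falls is uncertain. The step expected is an at least 6.4-fold lower number from compound 3 to compound 4 (0.80 log units; beyond the scatter). Compound 4 is estimated at 30000 nM, with a range of 3000 nM to 200000 nM.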

Compound 4, half-maximal cytotoxic concentration: 320 nM
Estimate against measurement, compound 4: 94-fold (1.97 log units) above, outside the stated range (below it).
By their numbers in this assay, from the lowest: compound 4; then compound 1; then compound 2.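

In this assay the change of linking atom outweighs the change of ring size at this position: cyclohexyloxy in place of cyclohexylsulfanyl brings an at least 600-fold lower number from compound 3 to compound 4 (2.77 log units; beyond the scatter), and cyclohexyl in place of cyclopentyl brings only a 3.3-fold lower number from compound 1 to compound 4 (0.52 log units; beyond the scatter). Methyl in place of hydrogen on the aromatic carbon brings a 1000-fold lower number from compound 2 to compound 4 (3.00 log units; beyond the scatter), so the low number depends on that group as well. Compound 3 holds a limit, not a number, so the first step has no exact size: the limit of >= 192000 nM in this assay, at which 1 of the 4 values shown sits.

The compounds shown leave open how an amine or a longer chain in place of cyclohexyloxy would read in this assay.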